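Permeability of compound 4 estimated from a stereochemical series

The source may hold more compounds than are shown below. What is called first, only, known or untested is meant among the compounds shown, and "the series" means these compounds.

Three compounds share one core and differ only at a single saturated ring carbon. Compound 1 `Cn1cc(-c2nc3c(-c4ccc5c(c4)CCCC5NC(=O)c4nc(C(C)(C)C)no4)ccnc3[nH]2)cn1` is drawn without a configuration there; in an ADME assay on Caco-2 cells (Homo sapiens) for permeability, in the apical to basolateral direction (a higher number here means that the compound crosses the layer faster, a lower number that the compound crosses the layer more slowly), compound 1 gives 1 10^-6 cm/s. Compound 2 `Cn1cc(-c2nc3c(-c4ccc5c(c4)CCC[C@@H]5NC(=O)c4nc(C(C)(C)C)no4)ccnc3[nH]2)cn1` carries the S configuration, and in this assay compound 2 gives 5 10^-6 cm/s, the highest of the three numbers. Compound 3 `Cn1cc(-c2nc3c(-c4ccc5c(c4)CCC[C@H]5NC(=O)c4nc(C(C)(C)C)no4)ccnc3[nH]2)cn1` carries the R configuration, and in this assay compound 3 gives 1 10^-6 cm/s. The steps are a 5.0-fold higher number from compound 1 to compound 2 (0.70 log units; beyond the scatter), no change at the digits printed from compound 1 to compound 3 (within the scatter) and a 5.0-fold lower number from compound 2 to compound 3 (0.70 log units; beyond the scatter).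

Compound 4 `Cc1nn(C2CCOCC2)cc1-c1nc2c(-c3ccc4c(c3)CCC[C@@H]4NC(=O)c3nc(C(C)(C)C)no3)ccnc2[nH]1` keeps the S configuration of compound 2 and changes elsewhere: a group of 12 heavy atoms (9 carbon, 2 nitrogen, 1 oxygen; one five-membered aromatic ring with 2 hetero atoms, one six-membered non-aromatic ring with 1 hetero atom) in place of a group of 6 heavy atoms (4 carbon, 2 nitrogen; one five-membered aromatic ring with 2 hetero atoms), on an aromatic carbon. For the measured compounds named here, none of the measured steps touches this group; all three concern the stereocentre alone, so they give no direct guidance on the size or direction of the new step. Compound 4 is therefore expected to stay close to compound 2, with a step of a 1.3-fold lower number from compound 2 to compound 4 (0.10 log units; within the scatter) within the scatter. Compound 4 is estimated at 4 10^-6 cm/s in this assay, within 1.5 10^-6 cm/s to 10 10^-6 cm/s.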

Compound 4, apparent permeability in the Caco-2 assay: 1.3 10^-6 cm/s
Estimate against measurement, compound 4: 3.1-fold (0.49 log units) above; the measured number lies below the stated range.
By their numbers in the Caco-2 assay, from the lowest: compounds 1, 3 and 4 (each within the scatter of the next); then compound 2.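

With the S configuration held, putting the larger group in place of the 1-methyl-1H-pyrazol-4-yl group on this aromatic carbon gives, in the Caco-2 assay, a 3.8-fold lower number from compound 2 to compound 4 (0.59 log units; beyond the scatter). For the compounds shown here, the earlier compounds varied only the stereocentre, so this is the first sign that the reading in this assay also responds to a change away from it, and that the step is not negligible. In a physicochemical assay for solubility, in simulated intestinal fluid (a higher number here means a more soluble compound, a lower number a less soluble compound), compound 2 gives 190 ug/mL and compound 4 gives 33 ug/mL. The exchange also tells on solubility in the physicochemical assay: the measured solubility of compound 2, 190 ug/mL, and of compound 4, 33 ug/mL, a 5.8-fold lower number (0.76 log units; beyond the scatter)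

The entering group differs in more than one feature, so the compounds shown do not separate the contribution of its six-membered ring with the oxygen from that of the rest of the group. As far as these compounds go, it also remains open whether a smaller group, such as an ethyl, or an amine such as piperidine, on this carbon would keep the readings of compound 2.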